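The source may report more compounds than this note shows. Statements on the series, on what has been measured and on what is new or still open speak of the compounds shown alone.

Compound 1, `Clc1ccc(Cc2nn3cc(-c4ccc(Br)cc4)nc3s2)cc1`: in a functional assay on L1210 cells (Mus musculus) for cytotoxicity, with a stated time of 48 h (a higher number here means a weaker inhibitor, a lower number a stronger inhibitor), compound 1 gives > 250000 nM, which is a limit of the assay.
Compound 2, `Cc1ccc(-c2cn3nc(Cc4ccc(Cl)cc4)sc3n2)cc1`: compound 2 gives > 250000 nM, also a limit of the assay.
Compound 3, `Clc1ccc(Cc2nn3cc(-c4ccc(Cl)cc4Cl)nc3s2)cc1`: compound 3 gives 247000 nM.

Compound 2 stands at a limit in this assay rather than at a number. Two of the three measured values share that limit, (the limit of > 250000 nM in this assay, at which 2 of the 3 values shown sit), and only compound 3 yields a number. The steps among the measured compounds are: a step that the two limits leave unreadable from compound 1 to compound 2; an at least 1.0-fold lower number from compound 1 to compound 3 (0.00 log units; that floor lies within the scatter); an at least 1.0-fold lower number from compound 2 to compound 3 (0.00 log units; that floor lies within the scatter). None of them reaches beyond the scatter.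

Compound 4, `O=[N+]([O-])c1ccc(-c2cn3nc(Cc4ccc(Cl)cc4)sc3n2)cc1`, differs from compound 2 by nitro in place of methyl on an aromatic carbon. Among the compounds with values here, no measured step exchanges a methyl for a nitro, so no step bears directly on this change, and the three steps that are known give no direction. The expectation for compound 4 in this assay is therefore no step beyond the scatter, and most likely a further limit; the estimate means a number no higher from compound 2 to compound 4 (the limit leaves the size open). Compound 4 is estimated at 250000 nM, with a range from 100000 nM to 600000 nM.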

Compound 4, half-maximal inhibitory concentration: 214000 nM
Compound 4: middle estimate off by 1.2-fold (0.07 log units), on the high side, within the range that was stated.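

In this assay, this aromatic carbon, para to a large group, now carries a substituent that gives a number rather than a limit, and the change can be read at least as a floor. The two floors are an at least 1.1-fold lower number from compound 2 to compound 4 (0.06 log units; that floor lies within the scatter) and an at least 1.1-fold lower number from compound 1 to compound 4 (0.06 log units; that floor lies within the scatter). Nitro in place of methyl or bromo therefore brings no shift that can be told from the scatter, and the series stays at the edge of what this read-out can resolve: the limit of > 250000 nM in this assay, at which 2 of the 4 values shown sit.

From the compounds shown here alone, the values of compound 1 and compound 2 are limits, so the true size of both steps remains open. Going by these compounds, whether an amine or a carboxylic acid on this same aromatic carbon would move the number beyond the scatter also remains open.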